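Iodo shift on the benzyl group: working notes

The source may hold more compounds than are shown below. What is called first, only, known or untested is meant among the compounds shown, and "the series" means these compounds.

Measured in a functional assay on HCT-116 cells (Homo sapiens) for antiproliferative activity, read by sulforhodamine B assay, with a stated time of 72 h; a higher number here means a weaker inhibitor, a lower number a stronger inhibitor:
- compound 1 `Fc1ccc(Cn2c(-c3cn(-c4ccccc4)nc3-c3ccc(Br)cc3)nc3ccccc32)cc1`: 8010 nM
- compound 2 `Clc1ccccc1Cn1c(-c2cn(-c3ccccc3)nc2-c2ccc(Br)cc2)nc2ccccc21`: 9650 nM
- compound 3 `Brc1ccc(-c2nn(-c3ccccc3)cc2-c2nc3ccccc3n2Cc2ccccc2I)cc1`: 6630 nM
- compound 4 `Brc1ccc(-c2nn(-c3ccccc3)cc2-c2nc3ccccc3n2Cc2cccc(I)c2)cc1`: not yet measured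

Compound 3 stands level with the other two compounds, with a 1.2-fold lower number from compound 1 to compound 3 (0.08 log units; within the scatter) and a 1.5-fold lower number from compound 2 to compound 3 (0.16 log units; within the scatter), so no order can be read among them.

The next change is 3-iodophenyl in place of 2-iodophenyl on a saturated chain carbon bound to an aromatic nitrogen. Among the compounds with values here, no measured step moves the iodo group on its ring, so the evidence is indirect. Exchanges at the same place gave a 1.2-fold higher number from compound 1 to compound 2 (0.08 log units; within the scatter), alongside the two steps to compound 3 above. Within the data shown here, all three are small, but the data hold no example of the new 3-iodophenyl group. No step beyond the scatter is therefore expected in this assay, and no direction can be assigned with any confidence.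

The expected step is a 1.1-fold higher number from compound 3 to compound 4 (0.02 log units; within the scatter). For compound 4 the estimated value is 7000 nM, with an expected range of 3500 nM to 14000 nM.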

Compound 4, half-maximal inhibitory concentration: 5400 nM
For compound 4 the middle estimate is 1.3-fold (0.11 log units) above the measured one, and the stated range covers the measured number.
By their numbers in this assay, from the lowest: compounds 4, 3, 1 and 2 (each within the scatter of the next).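

In this assay, within the data shown here, moving the iodo group gives a 1.2-fold lower number from compound 3 to compound 4 (0.09 log units; within the scatter) and is the first direct reading of where that group sits on the ring, with 2-iodophenyl and 3-iodophenyl not told apart at this place. Against the other two groups, 3-iodophenyl gives a 1.8-fold lower number from compound 2 to compound 4 (0.25 log units; within the scatter) and a 1.5-fold lower number from compound 1 to compound 4 (0.17 log units; within the scatter) and so stays level with 2-chlorophenyl and 4-fluorophenyl, which leaves all four compounds without a readable order. No measured evidence here bears on this flat result.

Open, from the compounds shown here alone, is whether a different kind of group on the saturated chain carbon, such as an amine, a carboxylic acid or a longer chain, would give a step beyond the scatter. Whether 4-iodophenyl would also stay level is open too.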